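This account rests on a few compounds, and the source may have more. Where it says the series, first, only, none or still open, it means among the compounds named here.

Measured so far in a functional assay on A549 cells (Homo sapiens) for inhibition, read by MTT assay, with a stated time of 48 h; on this read-out higher numbers stand for weaker inhibition and lower numbers for stronger inhibition:

- compound 1, `COc1cc(/C=N/Nc2nc(-c3ccc(C(F)(F)F)cc3)cs2)c(Br)c(Br)c1OC`: 17600 nM
- compound 2, `COc1cc(/C=N/Nc2nc(-c3ccc(F)c(F)c3)cs2)c(Br)c(Br)c1OC`: 8380 nM

Going by the values given here, of these two numbers, compound 2 gives the lower one, and its only neighbour is compound 1, which sits at a 2.1-fold lower number from compound 1 to compound 2 (0.32 log units; beyond the scatter). That single step, from one fluorinated phenyl to another, is the whole of what has been measured here.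

Compound 3, `COc1cc(/C=N/Nc2nc(-c3ccccc3)cs2)c(Br)c(Br)c1OC`, is the next compound to be tested. It differs from compound 2 in one place: phenyl in place of 3,4-difluorophenyl on an aromatic carbon. Both fluorines are removed and nothing replaces them.

Among the compounds with values here, only one measured step bears on this at all, and it does so loosely: a 2.1-fold lower number from compound 1 to compound 2 (0.32 log units; beyond the scatter) shows that trading a trifluoromethyl-bearing phenyl for a difluorophenyl made a modest difference. Within the data shown here, no measured pair shows what happens when the phenyl carries no fluorine. On that thin basis, a small step in this assay is expected for compound 3, of uncertain direction and likely within the scatter, amounting to a 1.3-fold higher number from compound 2 to compound 3 (0.12 log units; within the scatter). The expected value for compound 3 is 11000 nM, with a range from 4000 nM to 30000 nM.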

Compound 3, half-maximal inhibitory concentration: 15300 nM
The estimate for compound 3 lay 1.4-fold (0.14 log units) below the measured number, and the stated range covers the measured number.
By their numbers in this assay, from the lowest: compounds 2, 3 and 1 (each within the scatter of the next, the first and the last beyond it).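

Removing both fluorines from the phenyl in this assay gives a 1.8-fold higher number from compound 2 to compound 3 (0.26 log units; within the scatter) and so compound 3 cannot be told apart from compound 2. Replacing the trifluoromethyl with hydrogen gives a 1.2-fold lower number from compound 1 to compound 3 (0.06 log units; within the scatter) and so compound 3 cannot be told apart from compound 1 either. Plain phenyl on this aromatic carbon, next to the ring nitrogen, is therefore not shown to differ from either fluorinated phenyl, even though compound 1 and compound 2 do stand apart from each other, and nothing available explains why the three numbers fall where they do.

As far as these compounds go, all three compounds carry a six-membered carbon ring at this position, so it remains open what a phenyl bearing an amine or a carboxylic acid would do, or what a longer chain in place of the ring would do. From the compounds shown here alone, it is also open whether any such group would shift the number beyond the scatter from plain phenyl, and in which direction.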